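A few compounds are considered here, and "the series" means these few. Any claim that something is new, unique, unknown or untested is made for them only; others in the source may bear on it.

In a functional assay on HEK293 cells for agonist activity at G-protein coupled receptor 39 (Homo sapiens), read by scintillation proximity assay and inositol phosphate accumulation, with a stated time of 75 min (a lower number here means that less compound is needed, a higher number that more compound is needed for the effect), three compounds sharing one core have been measured. Compound 1 `Cc1nn(-c2ncnc3nc[nH]c23)c2c1C(C(=O)NCc1ccc(F)cc1)CC(=O)N2` gives 1220 nM, compound 2 `CCCCCCCCOC1CC(=O)Nc2c1c(C)nn2-c1ncnc2nc[nH]c12` gives 388 nM, and compound 3 `Cc1nn(-c2ncnc3nc[nH]c23)c2c1C(C(=O)N(C)c1nccs1)CC(=O)N2` gives 3300 nM, which is the highest of the three numbers. The change that leads to compound 4 `Cc1nn(-c2ncnc3nc[nH]c23)c2c1C(C(=O)N(C)c1ccccc1)CC(=O)N2` is phenyl in place of 1,3-thiazol-2-yl on an amide-type nitrogen. Among the compounds with values here, only one measured step touches the same amide-type nitrogen: a 2.7-fold higher number from compound 1 to compound 3 (0.43 log units; beyond the scatter), where the whole substituent on the carbonyl carbon was exchanged. The other step, an 8.5-fold higher number from compound 2 to compound 3 (0.93 log units; beyond the scatter), alters a different part of the molecule. Within the data shown here, no measured pair isolates a swap of one aromatic ring for another on this nitrogen, so the step is expected to stay within the scatter, a 1.2-fold lower number from compound 3 to compound 4 (0.07 log units; within the scatter). Compound 4 is therefore estimated at 2800 nM, within a range from 1000 nM to 8000 nM.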

Compound 4, half-maximal effective concentration: 5220 nM
Compound 4: middle estimate off by 1.9-fold (0.27 log units), on the low side, within the range that was stated.
By their numbers in this assay, from the lowest: compound 2; then compound 1; then compounds 3 and 4 (each within the scatter of the next).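

Within the data shown here, the swap of 1,3-thiazol-2-yl for phenyl on the amide-type nitrogen (a 1.6-fold higher number from compound 3 to compound 4 (0.20 log units; within the scatter)) is the first measured exchange of one aromatic ring for another at this place, and it stays within the scatter. The methyl(phenyl)carbamoyl compound also keeps a higher number than the compounds with (4-fluorobenzyl)amino (a 4.3-fold higher number from compound 1 to compound 4 (0.63 log units; beyond the scatter)) and octyloxy (a 13-fold higher number from compound 2 to compound 4 (1.13 log units; beyond the scatter)). Nothing available explains these steps. On these data alone, whether a pyridine ring, a phenyl ring carrying fluorine, or a hydrogen in place of the methyl on this nitrogen would move the number remains open.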